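Methyl for Hydrogen on the Outer Phenyl Ring

The compounds below may be only part of what the source reports. "The series", "measured", "known", "first", "only" and "open" are said of these compounds alone.

For the measured compounds named here, compound 2, `Oc1ccc(-c2nnc(Nc3csc(-c4ccccc4)c3)s2)cc1`, is the only member of this small set with a number in a functional assay on MCF7 cells (Homo sapiens) for inhibition, read by colorimetric assay and MTT assay, with a stated time of 72 h; on this read-out higher numbers stand for weaker inhibition and lower numbers for stronger inhibition. In this assay, going by the values given here, compound 2 gives 24000 nM, the sole value shown, so it stands alone without a comparison. Compound 1, `COc1ccc(-c2nnc(Nc3csc(-c4ccc(C)cc4)c3)s2)cc1`, carries a methoxy group in place of the hydroxyl and a methyl on the other phenyl ring, but in this assay compound 1 gives "not determined" (no result reported), so no result was reported for it. Compound 3, `Cc1ccc(-c2cc(Nc3nnc(-c4ccc(O)cc4)s3)cs2)cc1`, differs from compound 2 in one place only: methyl in place of hydrogen on an aromatic carbon, on an aromatic carbon of a six-membered aromatic ring of carbon only, para to a large group; read one bond further out, phenyl becomes 4-methylphenyl. Among the compounds with values here, no measured pair shows what such a change does here. A step of about a 1.2-fold lower number from compound 2 to compound 3 (0.08 log units; within the scatter) is therefore expected, that is, none beyond the usual scatter. Compound 3 is estimated at 20000 nM, within a range from 8000 nM to 50000 nM.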

Compound 3, half-maximal inhibitory concentration: 8000 nM
Compound 3: the middle estimate sits 2.5-fold (0.40 log units) above what was measured; the measured number falls inside the stated range.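

Methyl in place of hydrogen on an aromatic carbon, para to a large group, gives a 3.0-fold lower number from compound 2 to compound 3 (0.48 log units; beyond the scatter) in this assay, so this position on the outer ring responds to even a single added carbon. For the compounds shown here, this is the first measured pair in the set, and it shows that phenyl to 4-methylphenyl goes with stronger inhibition here, a direction that compound 2 alone and compound 1, without a result, could not show. Nothing given here accounts for the step.

From the compounds shown here alone, whether a longer chain such as ethyl, or an amine, at this same place would move the number in the same direction remains open. Also open, going by these compounds, is what methoxy in place of the hydroxyl does to compound 3, as compound 1 has no number to compare.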